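The source may report more compounds than this note shows. Statements on the series, on what has been measured and on what is new or still open speak of the compounds shown alone.

Working notes on the series. Compound 1 `O=C(Nc1nnc(-c2cccc(O)c2O)s1)c1ccccc1` and compound 2 `CC(=O)Nc1nnc(-c2cccc(O)c2O)s1` share one core; compound 3 `CC(=O)Nc1nnc(-c2ccc(O)c(O)c2)s1` has the same atoms joined differently, and the difference between the two cores is not broken down here. In a functional assay on A549 cells (Homo sapiens) for cytotoxicity, read by MTT assay, with a stated time of 72 h (a lower number here means a stronger inhibitor, a higher number a weaker inhibitor), compound 1 gives 12300 nM. In this assay compound 2 gives 200000 nM, while compound 3 gives 133000 nM, a pair within the usual scatter of each other. The change phenyl in place of methyl on a carbonyl carbon made a 16-fold lower number from compound 2 to compound 1 (1.21 log units; beyond the scatter). Compound 4 `O=C(Nc1nnc(-c2ccc(O)c(O)c2)s1)c1ccccc1`, not yet measured, is the counterpart of compound 3 with the same change, (phenyl in place of methyl on a carbonyl carbon), at the same place. In this assay the expected step is a 16-fold lower number from compound 3 to compound 4 (1.19 log units; beyond the scatter), resting on the step the same change made, a 16-fold lower number from compound 2 to compound 1 (1.21 log units; beyond the scatter). Compound 4 is therefore estimated at 8500 nM, with most repeats expected between 3000 nM and 25000 nM.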

Compound 4, half-maximal inhibitory concentration: 13000 nM
Compound 4: middle estimate off by 1.5-fold (0.18 log units), on the low side; low and high end bracket the measured number.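

In this assay, phenyl in place of methyl on a carbonyl carbon gave a 10-fold lower number from compound 3 to compound 4 (1.01 log units; beyond the scatter), and this step stands beside the earlier one on the other core: the same change on two cores in this assay, a 16-fold lower number (1.21 log units; beyond the scatter) from compound 2 to compound 1 and a 10-fold lower number (1.01 log units; beyond the scatter) from compound 3 to compound 4, 1.6-fold (0.20 log units) apart, within the scatter of two such steps. The change therefore carries from one of these two cores to the other with no difference that can be told apart from the scatter. This rests on two pairs in one assay, and it shows neither why the number falls nor that the step would hold on any further core.

The compounds shown leave open what other groups on the carbonyl carbon would do, such as a longer chain, an amine or a substituted phenyl. Also open, on these data alone, is the effect of replacing the hydroxyl groups, for instance with methoxy groups.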